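The compounds below may be only part of what the source reports. "The series", "measured", "known", "first", "only" and "open" are said of these compounds alone.

The compounds measured so far:

Compound 1, `O=C(C=C1CCN(C(=O)c2ccc(F)cc2)CC1)N[C@@H]1CCN(Cc2ccc3cc(F)ccc3c2)C1`, gives 237 mL/min/kg in an in vitro ADME assay on microsomes from liver (Homo sapiens) for metabolic stability; a higher number here means faster removal of the compound, a lower number slower removal.
Compound 2, `O=C(C=C1CCN(C(=O)c2ccccc2O)CC1)N[C@@H]1CCN(Cc2ccc3cc(F)ccc3c2)C1`, gives in this assay only a limit, < 64 mL/min/kg.

Within the data shown here, compound 1 stands as the only value reported as a number in this assay; the value for compound 2 is a limit, as noted in the limit of < 64 mL/min/kg in this assay, at which 1 of the 2 values shown sits. Compound 3, `O=C(C=C1CCN(C(=O)c2ccccc2F)CC1)N[C@@H]1CCN(Cc2ccc3cc(F)ccc3c2)C1`, differs from compound 1 by 2-fluorophenyl in place of 4-fluorophenyl on a carbonyl carbon. Among the measured compounds shown here, no measured step makes this same change. For the measured compounds named here, the only measured step, an at least 3.7-fold lower number from compound 1 to compound 2 (0.56 log units; beyond the scatter), puts a different group on the same carbonyl carbon and shows that a change there can move the number well beyond the scatter. Since the step to compound 3 keeps the fluorophenyl group, the step of a 1.2-fold lower number from compound 1 to compound 3 (0.07 log units; within the scatter) is expected to stay within the scatter, with no direction favoured. Compound 3 is therefore estimated at 200 mL/min/kg in this assay, ranging from 90 mL/min/kg to 420 mL/min/kg.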

Compound 3, clearance: 590 mL/min/kg
The estimate for compound 3 lay 3.0-fold (0.47 log units) below the measured number; the measured number lies above the stated range.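

In this assay, the swap of 4-fluorophenyl for 2-fluorophenyl on the carbonyl carbon, which leaves the atoms the same, gives a 2.5-fold higher number from compound 1 to compound 3 (0.40 log units; beyond the scatter), so where the fluorine sits on this phenyl group matters, and changes at this place can now be seen to move the number in either direction. Fluoro in place of hydroxy on an aromatic carbon gives an at least 9.2-fold higher number from compound 2 to compound 3 (0.96 log units; beyond the scatter), a step that sets the two groups on the same 2-substituted phenyl apart. That step rests on a limit of the assay, not a number, for compound 2: the limit of < 64 mL/min/kg in this assay, at which 1 of the 3 values shown sits.

The compounds shown leave open how unsubstituted phenyl, 2-chlorophenyl or 2-methoxyphenyl on the same carbonyl carbon would read in this assay. They also leave open whether the hydroxy group of compound 2 would give a low number at the 4-position of the phenyl group.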